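Removing a drawn stereocentre from a hydroxyurea alkyne

The source may hold more compounds than are shown below. What is called first, only, known or untested is meant among the compounds shown, and "the series" means these compounds.

Compound 1, with the structure `C[C@@H](C#Cc1cccc(C(=O)NCc2ccccc2C(F)(F)F)c1)N(O)C(N)=O`, is measured in an assay for inhibition of Polyunsaturated fatty acid 5-lipoxygenase (Homo sapiens), read by HPLC, with stated times of 15 min and 10 min (on this read-out higher numbers stand for weaker inhibition and lower numbers for stronger inhibition), where it gives 700 nM. Among the three measured compounds this is the second highest number. Compound 2, `CC(C#Cc1ccc(C(=O)NCc2ccccc2C(F)(F)F)cc1)N(O)C(N)=O`, gives 1000 nM in this assay, which lies within the scatter of compound 1. Compound 3, `CC(C#Cc1cccc(C(=O)NCCC(c2ccccc2)c2ccc(Cl)cc2)c1)N(O)C(N)=O`, gives 120 nM, a clearly lower number than compound 1. Compound 4, `CC(C#Cc1cccc(C(=O)NCc2ccccc2C(F)(F)F)c1)N(O)C(N)=O`, has not yet been measured. It differs from compound 1 only in this way: the two compounds have the same atoms and bonds; at least one stereo element is drawn with a configuration in one of them and without one in the other: 1 of 1 stereo elements differ; a stereocentre at a saturated chain carbon is drawn S in compound 1 and without a configuration in compound 4. For the measured compounds named here, no step between measured compounds shows what such a change does. The expected step from compound 1 to compound 4 is a 1.4-fold higher number from compound 1 to compound 4 (0.15 log units; within the scatter), small and towards a higher number, within the scatter. Compound 4 is estimated at 1000 nM, with a range from 400 nM to 2500 nM.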

Compound 4, half-maximal inhibitory concentration: 700 nM
Estimate against measurement, compound 4: 1.4-fold (0.15 log units) above; the measured number falls inside the stated range.
By their numbers in this assay, from the lowest: compound 3; then compounds 1, 4 and 2 (each within the scatter of the next).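

In this assay the new comparison gives no change at the digits printed from compound 1 to compound 4 (within the scatter). For the compounds shown here, this is the first pair here that isolates the saturated chain carbon, and at this position dropping the drawn S configuration leaves the number where it was. The pair differs in one thing only: the fact that one of compounds 1 and 4 is drawn with a defined configuration and the other without, at the place where they differ

As far as these compounds go, the undrawn configuration of compound 4 does not say which forms the sample holds, so how a compound drawn R would read stays open. Also open, from the compounds shown here alone, is what a longer chain, such as an ethyl group, would do at this carbon.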